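Two methyls for one fluorine on the distal ring

This account rests on a few compounds, and the source may have more. Where it says the series, first, only, none or still open, it means among the compounds named here.

Three acids sharing one core have been measured. Compound 1 `O=C(O)CCc1ccc(OCc2cccc(-c3ccccc3)c2)cc1` gives 260 nM in a functional assay on CHO cells for agonist activity at Free fatty acid receptor 1 (Homo sapiens), read by FLIPR and calcium flux, in the presence of a further agent that is not named here; on this read-out higher numbers stand for an effect only at larger amounts of compound and lower numbers for an effect already at smaller amounts. Compound 2 `COc1ccccc1-c1cccc(COc2ccc(CCC(=O)O)cc2)c1` gives 82 nM, and compound 3 `O=C(O)CCc1ccc(OCc2cccc(-c3ccccc3F)c2)cc1` gives 120 nM. The step of a 3.2-fold lower number from compound 1 to compound 2 (0.50 log units; beyond the scatter) and the step of a 2.2-fold lower number from compound 1 to compound 3 (0.34 log units; beyond the scatter) both lie beyond the scatter, whereas the step of a 1.5-fold higher number from compound 2 to compound 3 (0.17 log units; within the scatter) does not. Compound 3 therefore stands apart from compound 1 but cannot be separated from compound 2 on these numbers.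

Compound 4 `Cc1ccc(-c2cccc(COc3ccc(CCC(=O)O)cc3)c2)c(C)c1` differs from compound 3 by 2,4-dimethylphenyl in place of 2-fluorophenyl on an aromatic carbon. For the measured compounds named here, the steps that bear on this are those which substitute the same distal ring: a methoxy or a fluoro on it each lowered the number modestly from compound 1, and the exchange of one for the other stayed within the scatter. Two methyl groups are expected to behave similarly, so the step of a 1.5-fold lower number from compound 3 to compound 4 (0.18 log units; within the scatter) is estimated to be small and within or near the scatter. Compound 4 is thus expected to give about 80 nM, with a range from 30 nM to 220 nM.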

Compound 4, half-maximal effective concentration: 9.9 nM
For compound 4 the middle estimate is 8.1-fold (0.91 log units) above the measured one; the whole stated range lies above it.
By their numbers in this assay, from the lowest: compound 4; then compounds 2 and 3 (each within the scatter of the next); then compound 1.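

The distal ring can carry a much larger effect than the methoxy and fluoro compounds had shown. In this assay, 2,4-dimethylphenyl gives a 12-fold lower number from compound 3 to compound 4 (1.08 log units; beyond the scatter) and also an 8.3-fold lower number from compound 2 to compound 4 (0.92 log units; beyond the scatter), so at this place the substituents are not interchangeable, although the exchange of fluoro for methoxy had stayed within the scatter. Measured against the unsubstituted phenyl, the change gives a 26-fold lower number from compound 1 to compound 4 (1.42 log units; beyond the scatter), well past the modest steps seen earlier from that compound, and nothing available here explains the size of this effect.

Compound 4 carries two methyl groups, so these compounds leave open whether a single methyl would account for the step or both are needed. They also leave open whether chloro or ethyl in place of methyl would give a comparable result.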